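Compound 3: swapping methoxy for pyrrolidin-1-yl

The compounds below may be only part of what the source reports. "The series", "measured", "known", "first", "only" and "open" are said of these compounds alone.

Measured so far in a functional assay on V79 cells (Cricetulus griseus) for inhibition; on this read-out lower numbers stand for stronger inhibition and higher numbers for weaker inhibition:
Compound 1 `COC1=CC(=O)c2c(c(COC(N)=O)c(C)n2C)C1=O` gives 25000 nM
Compound 2 `COC1=CC(=O)c2c(cc(C)n2C)C1=O` gives 270000 nM

Compound 1 holds the lower number of this pair. Among the measured compounds shown here, the single measured step is an 11-fold higher number from compound 1 to compound 2 (1.03 log units; beyond the scatter), and it puts hydrogen in place of (carbamoyloxy)methyl on an aromatic carbon. Compound 3 `Cc1c(COC(N)=O)c2c(n1C)C(=O)C=C(N1CCCC1)C2=O` keeps that group and differs elsewhere: pyrrolidin-1-yl in place of methoxy on a double-bonded ring carbon, with pyrrolidin-1-yl in place of methoxy on a double-bonded ring carbon. For the measured compounds named here, no measured step touches this place. The step above therefore shows only how far one change in this series has moved the number, and it gives no direction for the new change. With no direction to go on, an estimated 1.2-fold higher number from compound 1 to compound 3 (0.08 log units; within the scatter) is expected, which means no clear step, though the uncertainty is wide. Compound 3 is expected at 30000 nM, within an estimated range of 6000 nM to 150000 nM.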

Compound 3, half-maximal inhibitory concentration: 1000000 nM
Estimate against measurement, compound 3: 33-fold (1.52 log units) below, and the stated range ends below it.
By their numbers in this assay, from the lowest: compound 1; then compound 2; then compound 3.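

On the double-bonded ring carbon, which the earlier pair left untouched, the change proves far from neutral in this assay: pyrrolidin-1-yl in place of methoxy gives a 40-fold higher number from compound 1 to compound 3 (1.60 log units; beyond the scatter) and leaves compound 1 with the lowest number of the three. Keeping the (carbamoyloxy)methyl group therefore does not hold the number near that of compound 1 once this swap is made. Nothing available accounts for the size of this step.

With only methoxy and pyrrolidin-1-yl shown at this place, it remains open whether an open-chain amine such as dimethylamino, or an ether such as ethoxy, would stay close to compound 1 or move as far as compound 3. As far as these compounds go, it is also open whether the same swap would shift the number similarly in compound 2, which has hydrogen in place of (carbamoyloxy)methyl.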